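Adding Bromo to a Nitrile Compound

The source may report more compounds than this note shows. Statements on the series, on what has been measured and on what is new or still open speak of the compounds shown alone.

- Compound 1 `Brc1cncc2nccn12`: 18 nM
- Compound 2 `N#Cc1cn2ccncc2n1`: > 167 nM
- Compound 3 `N#Cc1cn2c(Br)cncc2n1`: not yet measured

Compound 2 stands only at a limit in a functional assay on the whole organism for inhibition, with Cavia porcellus as the target (on this read-out lower numbers stand for an effect already at smaller amounts and higher numbers for an effect only at larger amounts of compound), and its > 167 nM is a limit of the assay, not a number. Compound 3 keeps the nitrile of compound 2 and carries bromo in place of hydrogen on an aromatic carbon, next to the ring nitrogen (bromo in place of hydrogen on an aromatic carbon). Going by the values given here, no measured pair shows this change directly, so the forecast rests on a single comparison. Compound 1, which also carries a bromo group, gives 18 nM in this assay. On that basis, a shift toward lower numbers, beyond the usual scatter, is expected, with an estimated at least 4.1-fold lower number from compound 2 to compound 3 (0.62 log units; beyond the scatter). The outcome remains uncertain, and the range is kept wide. For compound 3 the estimated value is 40 nM, with an expected range of 8 nM to 200 nM.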

Compound 3, concentration for half-maximal effect: > 15 nM
Compound 3 gave a limit, no number; the forecaster's own chance of this, stated with the estimate: 15%; the middle value lies beyond the limit too.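

In this assay compound 3 gives > 15 nM, which is a limit and not a number. Its steps from compound 2 and from compound 1 cannot be read. The compounds shown leave open whether bromo in place of hydrogen on an aromatic carbon shifts the read-out of compound 2 at all.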